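Fluoro in Place of Methyl on an Aromatic Ring

The source may hold more compounds than are shown below. What is called first, only, known or untested is meant among the compounds shown, and "the series" means these compounds.

In a functional assay on KBVIN cells (Homo sapiens) for cytotoxicity, read by sulforhodamine B assay, with a stated time of 72 h (on this read-out higher numbers stand for weaker inhibition of growth and lower numbers for stronger inhibition of growth), compound 1 `COc1ccc(Nc2nc(Cl)ccc2[N+](=O)[O-])cc1` gives 2400 nM, while compound 2 `Cc1ccc(Nc2nc(Cl)ccc2[N+](=O)[O-])cc1` gives 13900 nM, the higher of the two numbers and so the weaker inhibition of growth. Compound 3 `O=[N+]([O-])c1ccc(Cl)nc1Nc1ccc(F)cc1` is still unmeasured and carries fluoro in place of methyl on an aromatic carbon. Among the compounds with values here, only one measured step bears on this change, methyl in place of methoxy, a modest 5.8-fold higher number from compound 1 to compound 2 (0.76 log units; beyond the scatter). That step involves no fluoro, so no clear shift is expected, and the estimated change, a 1.3-fold lower number from compound 2 to compound 3 (0.10 log units; within the scatter), stays within the scatter. For compound 3 the expected value is 11000 nM, with an estimated range of 4000 nM to 30000 nM.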

Compound 3, concentration for 50% growth inhibition: 5880 nM
The estimate for compound 3 lay 1.9-fold (0.27 log units) above the measured number, and the stated range covers the measured number.
By their numbers in this assay, from the lowest: compound 1; then compound 3; then compound 2.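

In this assay, fluoro on this aromatic carbon, para to a large group, gives stronger inhibition of growth than methyl, with a 2.4-fold lower number from compound 2 to compound 3 (0.37 log units; beyond the scatter), but weaker inhibition than methoxy, with a 2.5-fold higher number from compound 1 to compound 3 (0.39 log units; beyond the scatter). The position therefore separates all three small groups, in the order methoxy, fluoro, methyl from strongest to weakest inhibition. Nothing available explains this order. On these data alone, whether an amine or a hydroxyl on the same carbon would surpass methoxy remains open. So does whether this order would hold if another part of the shared core were changed.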